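Aryl ester variation on the sesquiterpene lactone core

The source may report more compounds than this note shows. Statements on the series, on what has been measured and on what is new or still open speak of the compounds shown alone.

Compound 1 `C=C1C(=O)O[C@@H]2CC(C)=C([C@@H](C)CCCOC(C)=O)[C@@H](OC(=O)COc3cccc(C(C)=O)c3)[C@H]12` carries a (3-acetylphenoxy)methyl ester on the shared core. In a functional assay on HeLa cells (Homo sapiens) for cytotoxicity, read by sulforhodamine B assay, with a stated time of 72 h (a higher number here means a weaker inhibitor, a lower number a stronger inhibitor), compound 1 gives 38600 nM, the highest number among the three measured compounds. Compound 2 `C=C1C(=O)O[C@@H]2CC(C)=C([C@@H](C)CCCOC(C)=O)[C@@H](OC(=O)COc3ccc(C(=O)OCCC)cc3)[C@H]12` gives 22900 nM, a difference of a 1.7-fold lower number from compound 1 to compound 2 (0.23 log units; within the scatter). Compound 3 `C=C1C(=O)O[C@@H]2CC(C)=C([C@@H](C)CCCOC(C)=O)[C@@H](OC(=O)c3ccccc3F)[C@H]12` gives 17000 nM, a difference of a 2.3-fold lower number from compound 1 to compound 3 (0.36 log units; beyond the scatter).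

Compound 4 `C=C1C(=O)O[C@@H]2CC(C)=C([C@@H](C)CCCOC(C)=O)[C@@H](OC(=O)c3cc(OC)c(OC)c(OC)c3)[C@H]12` is not yet measured. Relative to compound 1 the change is 3,4,5-trimethoxyphenyl in place of (3-acetylphenoxy)methyl on a carbonyl carbon. Within the data shown here, the step that bears on it is the one to compound 3, where an aryl group likewise replaced the (3-acetylphenoxy)methyl group on the carbonyl carbon and the number fell modestly, a 2.3-fold lower number from compound 1 to compound 3 (0.36 log units; beyond the scatter). The step to compound 2, which kept the phenoxymethyl ester, was within the scatter. Among the measured compounds shown here, a similar modest lowering is therefore expected for compound 4 in this assay, with the width of the range reflecting that only one comparable step exists. The expected step is a 2.4-fold lower number from compound 1 to compound 4 (0.38 log units; beyond the scatter). For compound 4 the estimate is 16000 nM, between 6000 nM and 40000 nM.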

Compound 4, half-maximal inhibitory concentration: 6540 nM
Beside the measured number, compound 4's estimate is 2.4-fold (0.39 log units) above it; low and high end bracket the measured number.
By their numbers in this assay, from the lowest: compound 4; then compounds 3, 2 and 1 (each within the scatter of the next, the first and the last beyond it).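

In this assay, the ester with an aryl group directly on the carbonyl carbon now shows a clear dependence on which aryl group it is: the 3,4,5-trimethoxyphenyl group gives a 5.9-fold lower number from compound 1 to compound 4 (0.77 log units; beyond the scatter) and, against the 2-fluorophenyl ester, gives a 2.6-fold lower number from compound 3 to compound 4 (0.41 log units; beyond the scatter) (both beyond the scatter as printed). The earlier lowering therefore cannot be read as a single effect of losing the (3-acetylphenoxy)methyl group, since the two aryl esters differ from each other. Nothing measured here gives a reason for that difference.

Still open, on these data alone, is whether the methoxy groups account for the lowering, and whether a single methoxy group, a hydroxyl or an amine on the phenyl ring would move the number further. Also open, as far as these compounds go, is whether these steps hold when the acetate on the side chain of the shared core becomes a free alcohol.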